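This account rests on a few compounds, and the source may have more. Where it says the series, first, only, none or still open, it means among the compounds named here.

Measured compounds:

Compound 1, `CCOC(=O)/C=C/c1cccc(OC)c1OCc1nc(C)c(C)nc1C`; in a functional assay on ECV-304 cells (Homo sapiens) for cytotoxicity, read by MTT assay, with stated times of 24 h and 12 h (a lower number here means that less compound is needed, a higher number that more compound is needed for the effect), compound 1 gives 3040000 nM.
Compound 2, `CCOC(=O)/C=C/c1cc(Br)cc(Br)c1OCc1nc(C)c(C)nc1C`; in this assay compound 2 gives 1590000 nM.
Compound 3, `COc1cccc(/C=C/C(=O)O)c1OCc1nc(C)c(C)nc1C`; in this assay compound 3 gives 3590000 nM.

All three compounds carry an ethenyl chain bearing a carbonyl group, attached to a benzene ring, which in turn is linked through an oxygen to the shared core. Compound 1 and compound 3 differ in one place only: hydrogen in place of ethyl on an oxygen next to a carbonyl group. That change gives a 1.2-fold higher number from compound 1 to compound 3 (0.07 log units; within the scatter), a step so small that the two values cannot be told apart.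

Compound 2 and compound 1 share this ester end but differ on the benzene ring; the difference between the two cores is not broken down here, and their values in this assay are within the usual scatter of each other.

Compound 4, `Cc1nc(C)c(COc2c(Br)cc(Br)cc2/C=C/C(=O)O)nc1C`, is not yet measured. It stands to compound 2 as compound 3 stands to compound 1: hydrogen in place of ethyl on an oxygen next to a carbonyl group. The place of the change reads the same in both pairs, so this is the same change, seen once already. Because the earlier step of a 1.2-fold higher number from compound 1 to compound 3 (0.07 log units; within the scatter) stayed within the scatter, the expected step from compound 2 to compound 4 in this assay is estimated to be similar, a 1.2-fold higher number from compound 2 to compound 4 (0.08 log units; within the scatter). Compound 4 is thus expected to give about 1900000 nM in this assay, with a likely range from 900000 nM to 4000000 nM.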

Compound 4, half-maximal effective concentration: 1970000 nM
The estimate for compound 4 lay 1.0-fold (0.02 log units) below the measured number; the measured number falls inside the stated range.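

In this assay, replacing ethyl with hydrogen on the oxygen next to a carbonyl group turns the ethoxycarbonyl end of compound 2 into a carboxy end and gives a 1.2-fold higher number from compound 2 to compound 4 (0.09 log units; within the scatter). Set beside the earlier example of this change, the result is the same on both cores, with no step that can be told apart from repeat-measurement noise and no detectable difference between the two steps: the same change on two cores in this assay, a 1.2-fold higher number (0.07 log units; within the scatter) from compound 1 to compound 3 and a 1.2-fold higher number (0.09 log units; within the scatter) from compound 2 to compound 4, 1.0-fold (0.02 log units) apart, within the scatter of two such steps. This shows only that the ester and the acid could not be separated in this assay on these two cores; it does not show that the change has no effect on other cores or in other assays, and it gives no explanation for the small steps.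

The compounds shown leave open whether a different replacement at this end of the molecule, such as an amide in place of the ester or a chain longer than ethyl on the same oxygen, would produce a step beyond the scatter. They also leave open how the ester-to-acid change would behave on a benzene ring carrying other groups, such as an amine or a nitrile.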